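The source may report more compounds than this note shows. Statements on the series, on what has been measured and on what is new or still open speak of the compounds shown alone.

In a functional assay on HCT-116 cells (Homo sapiens) for antiproliferative activity, read by sulforhodamine B assay (on this read-out higher numbers stand for weaker inhibition and lower numbers for stronger inhibition), compound 3 `O=C1NC(=O)c2ccc(-c3ccoc3)cc2/C1=C/Nc1ccc(CN2CCCCC2)cc1` gives 1900 nM and lies within the scatter of compound 1 `O=C1NC(=O)c2ccc(I)cc2/C1=C/Nc1ccc(CN2CCCCC2)cc1` at 2700 nM and of compound 2 `CN1CCN(c2ccc(N/C=C3\C(=O)NC(=O)c4ccc(-c5ccoc5)cc43)cc2)CC1` at 1200 nM in this small set. Compound 4 `O=C1NC(=O)c2ccc(-c3ccc(F)cc3)cc2/C1=C/Nc1ccc(CN2CCCCC2)cc1` follows from compound 3 by 4-fluorophenyl in place of furan-3-yl on an aromatic carbon with 4-fluorophenyl in place of furan-3-yl on an aromatic carbon. The closest measured precedent is a 1.4-fold lower number from compound 1 to compound 3 (0.15 log units; within the scatter) for furan-3-yl in place of iodo at the same place. The step of a 1.6-fold higher number from compound 2 to compound 3 (0.20 log units; within the scatter) concerns (piperidin-1-yl)methyl in place of 4-methylpiperazin-1-yl and bears on it only loosely. Going by the values given here, both stay within the scatter, and no aryl-for-aryl pair has been measured, so no clear direction is expected. The expected change is a 1.1-fold lower number from compound 3 to compound 4 (0.02 log units; within the scatter) and no larger than the scatter. For compound 4 the estimate in this assay is 1800 nM with 800 nM to 4000 nM as its expected range.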

Compound 4, half-maximal inhibitory concentration: 1000 nM
For compound 4 the middle estimate is 1.8-fold (0.26 log units) above the measured one; the range from low to high includes it.
By their numbers in this assay, from the lowest: compounds 4, 2, 3 and 1 (each within the scatter of the next, the first and the last beyond it).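

In this assay, the position also accepts a six-membered aromatic ring of carbon only: a 1.9-fold lower number from compound 3 to compound 4 (0.28 log units; within the scatter). Going by these compounds alone, the step of a 2.7-fold lower number from compound 1 to compound 4 (0.43 log units; beyond the scatter) is the first at this position to clear the scatter, so replacing iodo here can register in this assay. Nothing at hand accounts for this step.

From the compounds shown here alone, how a phenyl without the fluorine or a pyridin-3-yl would read at this position stays open. So does whether 4-fluorophenyl would read the same with 4-methylpiperazin-1-yl in place of (piperidin-1-yl)methyl.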